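Swapping the aryl group on compound 1 for 3-cyanophenyl

This account rests on a few compounds, and the source may have more. Where it says the series, first, only, none or still open, it means among the compounds named here.

Three compounds have been measured in an ADME assay (liver) for metabolic stability, with Liver microsome (Homo sapiens) as the target, read by LC-MS, using microsomes, with a stated time of 1 h, tested at 5 uM (on this read-out higher numbers stand for a more stable compound and lower numbers for a less stable compound), so far:

- Compound 1 `Cc1nc(-c2ccccc2)c(C(=O)N2CCN(c3cccc(C)c3C)CC2)o1` gives 29.8%
- Compound 2 `Cc1nc(-c2ccc(F)cc2)c(C(=O)N2CCN(c3cc(Cl)cc(Cl)c3)CC2)o1` gives 71.8%
- Compound 3 `COc1cc(OC)cc(N2CCN(C(=O)c3oc(C)nc3-c3ccc(F)cc3)CC2)c1` gives 12.9%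

Compound 1 stands second highest of the three, with compound 2 above it and compound 3 below it, both gaps beyond the usual scatter. The step followed here leads to compound 4 `Cc1nc(-c2ccccc2)c(C(=O)N2CCN(c3cccc(C#N)c3)CC2)o1`, which is still unmeasured. The change is this: 3-cyanophenyl in place of 2,3-dimethylphenyl on an amine nitrogen in a ring. In short, 3-cyanophenyl comes in place of 2,3-dimethylphenyl on an amine nitrogen in a ring.

Going by the values given here, one measured step touches that place: a number 58.9 percentage points lower from compound 2 to compound 3 (beyond the scatter). It is large and shows that a swap here can move the number far. Among the compounds with values here, it starts from 3,5-dichlorophenyl, however, and no measured step starts from compound 1, so it offers a scale more than a direction.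

The two compounds with methyl or methoxy groups on that phenyl are compound 1 at 29.8% and compound 3 at 12.9%, the two lower values. Compound 4 carries neither group. On this thin evidence, a moderate upward step in this assay is expected, smaller than the measured one. The estimated change is a number 15.2 percentage points higher from compound 1 to compound 4 (beyond the scatter), with wide uncertainty. For compound 4 the expected value is 45%, with an estimated range from 20% to 70%.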

Compound 4, percent of the compound remaining: 8%
Compound 4: the middle estimate sits 37 percentage points above what was measured, and the stated range ends above it.
By their numbers in this assay, from the lowest: compounds 4 and 3 (each within the scatter of the next); then compound 1; then compound 2.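

Unlike a number 58.9 percentage points lower from compound 2 to compound 3 (beyond the scatter), which began from 3,5-dichlorophenyl, the step of a number 21.8 percentage points lower from compound 1 to compound 4 (beyond the scatter) in this assay begins on the core of compound 1 and gives this position a direction on that core: 3-cyanophenyl in place of 2,3-dimethylphenyl brings the number down. It also shows that the absence of methyl and methoxy groups on that phenyl does not go with a higher number, since compound 4 carries neither group and gives 8%, a value within the scatter of compound 3 at 12.9%. The low values are therefore not confined to the methyl- and methoxy-bearing compounds, and nothing available bears on why the number fell.

The compounds shown leave open whether the high value of compound 2 depends on its 3,5-dichlorophenyl group alone or also on the 4-fluorophenyl group elsewhere on its core, as no single-place step links it to compound 1 or compound 4. They also leave open how a trifluoromethyl group in place of the nitrile on the same phenyl would read in this assay.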